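Extending Compound 1 with a Furan-Bearing Ethenyl Group

The compounds below may be only part of what the source reports. "The series", "measured", "known", "first", "only" and "open" are said of these compounds alone.

Compound 1 `c1coc(-c2ccnc(-c3cccs3)c2)c1` is one of two measured members of this small set. In a functional assay on HCT-15 cells (Homo sapiens) for antiproliferative activity (a higher number here means that more compound is needed for the effect, a lower number that less compound is needed), compound 1 gives 118000 nM. Compound 2 `c1ccc(-c2cc(-c3cccs3)cc(-c3ccco3)n2)cc1`, which carries an additional phenyl group on the shared core, stands in this assay level with compound 1 at the digits recorded: compound 2 gives 118000 nM, and the two readings lie within the scatter of each other, so no ordering between them can be drawn.

Compound 3 `C(=C/c1ccco1)\c1cc(-c2ccco2)cc(-c2cccs2)n1` has not yet been tested. Relative to compound 1 it carries 2-(furan-2-yl)ethenyl in place of hydrogen on an aromatic carbon. Going by the values given here, no measured pair in this set shows what such a change does in this assay, so any expectation rests only on the weak reading of compound 1 at 118000 nM and the equally weak reading of compound 2. Starting from so high a concentration, a gain seems somewhat more plausible than a loss, though a result within the scatter would not surprise. Compound 3 is therefore expected to come in around 60000 nM, within a range from 15000 nM to 150000 nM. This estimate corresponds to an expected step of a 2.0-fold lower number from compound 1 to compound 3 (0.29 log units; within the scatter).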

Compound 3, half-maximal effective concentration: 118000 nM
For compound 3 the middle estimate is 2.0-fold (0.29 log units) below the measured one; the range from low to high includes it.
By their numbers in this assay, from the lowest: compounds 1, 2 and 3 (each within the scatter of the next).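

Going by these compounds alone, putting 2-(furan-2-yl)ethenyl in place of hydrogen on the aromatic carbon next to the ring nitrogen gives no change at the digits printed from compound 1 to compound 3 (within the scatter) in this assay, and this is the first reading in the set of a single change at one place. It shows that this position carries the added group, with its five-membered aromatic ring and its double bond outside aromatic rings, while compound 3 stays within the scatter of compound 1, so this substitution gives no sign of improving or worsening the antiproliferative reading. Nothing at hand explains this result.

The compounds shown leave open whether this position responds to any other kind of substituent, such as an amine, a carboxylic acid or a longer saturated alkyl chain, since a single substitution cannot show whether the position is insensitive in general. They also leave open whether the double bond and the terminal furan would each give the same reading on their own, and whether a change elsewhere on the shared core would shift a reading this weak.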